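Switching a methyl for isobutoxy on the carbonyl

The source may report more compounds than this note shows. Statements on the series, on what has been measured and on what is new or still open speak of the compounds shown alone.

Of the compounds shown here, two sharing one core have been tested in a functional assay on WI-38 VA13 cells (Homo sapiens) for cytotoxicity; on this read-out lower numbers stand for an effect already at smaller amounts and higher numbers for an effect only at larger amounts of compound. Compound 1 `Cc1cc(C(=O)Nc2ccc3nc(NC(=O)C4CCCCC4)sc3c2)n(C)n1` gives 0.12 ug/mL. Compound 2 `CC(=O)Nc1nc2ccc(NC(=O)c3c(Cl)cccc3Cl)cc2s1` gives 0.6 ug/mL, the highest of the two numbers and, compared with compound 1, a gap beyond the scatter. Compound 3 `CC(C)COC(=O)Nc1nc2ccc(NC(=O)c3c(Cl)cccc3Cl)cc2s1` has not been measured; it differs from compound 2 in one place: isobutoxy in place of methyl on a carbonyl carbon. Among the compounds with values here, no such step is recorded between measured compounds, so the step from compound 2 is expected to be small, in either direction or none beyond the scatter: no change at the digits printed from compound 2 to compound 3 (within the scatter). Compound 3 is therefore expected to give about 0.6 ug/mL, between 0.15 ug/mL and 2.5 ug/mL.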

Compound 3, half-maximal effective concentration: 0.0035 ug/mL
Beside the measured number, compound 3's estimate is 170-fold (2.23 log units) above it, outside the stated range (below it).
By their numbers in this assay, from the lowest: compound 3; then compound 1; then compound 2.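

In this assay, the carbonyl carbon on the amide-type nitrogen proves to be a highly sensitive place: isobutoxy in place of methyl brings a 170-fold lower number from compound 2 to compound 3 (2.23 log units; beyond the scatter). Compound 1 and compound 2 differ in more than one place, so they could not reveal this sensitivity.

From the compounds shown here alone, whether the step comes from the oxygen of the isobutoxy or from its carbon chain stays open; methoxy or a plain isobutyl on the same carbonyl would separate the two. Nothing measured here explains the size of the step.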